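This account rests on a few compounds, and the source may have more. Where it says the series, first, only, none or still open, it means among the compounds named here.

Of the compounds shown here, two have been measured in a functional assay on liver (Sus scrofa) for inhibition of squalene monooxygenase (Homo sapiens), using microsomes; on this read-out lower numbers stand for stronger inhibition and higher numbers for weaker inhibition. Compound 1, `CCN(CC#CC#CC(C)(C)OC)Cc1cccc(OC[Si](C)(C)c2ccccc2C)c1`, gives 70 nM. Compound 2, `CCN(C/C=C/C#CC(C)(C)C)Cc1cccc(OC[Si](C)(C)c2ccccc2C(F)(F)F)c1`, gives 70 nM. On these figures compound 2 stands level with compound 1: the two values are the same at the digits shown, which lies within the scatter of the measurement.

Compound 3, `CCN(C/C=C/C#CC(C)(C)C)Cc1cccc(OC[Si](C)(C)CCc2ccccc2)c1`, has not yet been measured. It differs from compound 2 in one place: phenethyl in place of 2-(trifluoromethyl)phenyl on a silicon. The silicon keeps its three saturated chain carbons and exchanges one aromatic substituent for another.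

Going by the values given here, no measured pair shows what such an exchange at the silicon does, so the expectation can rest only on the two values known so far, both of which sit at the same level. The step of a 1.4-fold higher number from compound 2 to compound 3 (0.15 log units; within the scatter) is expected to be small, either none beyond the scatter or a slight weakening. Compound 3 is therefore estimated at 100 nM, with a likely range from 35 nM to 300 nM.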

Compound 3, half-maximal inhibitory concentration: > 10000 nM
Compound 3: a limit, no number; the forecaster's own chance of this, stated with the estimate: 3%; at least 100-fold (2.00 log units) between middle value and limit.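

The group on the silicon turns out to matter far more than the two earlier compounds could show: phenethyl in place of 2-(trifluoromethyl)phenyl gives an at least 140-fold higher number from compound 2 to compound 3 (2.15 log units; beyond the scatter). In this assay compound 3 gives > 10000 nM, which is a limit of the assay and not a number. Both groups carry one six-membered aromatic ring of carbon only, so having such a ring on the silicon is not enough to keep inhibition at this position.

The change removes the trifluoromethyl group and also puts a chain in front of the ring, and the compounds shown cannot separate these two parts; a plain phenyl or a benzyl group on the silicon would begin to do so. How much weaker compound 3 really is also stays open, as its value rests on a limit: the limit of > 10000 nM in this assay, at which 1 of the 3 values shown sits.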